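Bromo to Methyl: Expecting Little Change in Inhibition

The compounds below may be only part of what the source reports. "The series", "measured", "known", "first", "only" and "open" are said of these compounds alone.

Of the compounds shown here, three sharing one core have been measured in an assay on isolated protein for inhibition of aldehyde dehydrogenase 1A1 (Homo sapiens), read by spectrophotometry, tested at 10 uM; a higher number here means more inhibition at the concentration tested (going by the name of the read-out), a lower number less inhibition. Compound 1 `Cc1cccc(Cn2c(CN3CCN(C(=O)c4ccc([N+](=O)[O-])cc4)CC3)nc3ccccc32)c1` gives 24.3%. Compound 2 `Cc1cccc(Cn2c(CN3CCN(C(=O)c4cccs4)CC3)nc3ccccc32)c1` gives 60.8%, and compound 3 `Cc1cccc(Cn2c(CN3CCN(C(=O)c4ccc(Br)cc4)CC3)nc3ccccc32)c1` gives 25.8%. Among these three numbers, compound 3 stands second highest: the gap to compound 1 is within the scatter, whereas the gap to compound 2 is well beyond it. The two large steps seen so far, a number 36.5 percentage points higher from compound 1 to compound 2 (beyond the scatter) and a number 35 percentage points lower from compound 2 to compound 3 (beyond the scatter), both involve exchanging the whole ring on the carbonyl carbon, thiophen-2-yl against 4-nitrophenyl or 4-bromophenyl.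

Compound 4 `Cc1ccc(C(=O)N2CCN(Cc3nc4ccccc4n3Cc3cccc(C)c3)CC2)cc1` keeps the ring and alters only the group on it: methyl in place of bromo on an aromatic carbon. The step that bears most directly on this change is a number 1.5 percentage points higher from compound 1 to compound 3 (within the scatter), where one group on the same aromatic carbon, para to a large group, was exchanged for another and the number hardly moved. By that precedent, exchanging one small group for another at the same place is expected to produce no step beyond the scatter, a number 1.2 percentage points higher from compound 3 to compound 4 (within the scatter). Compound 4 is therefore estimated at 27%, with a range from 12% to 42%.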

Compound 4, a percentage reported as inhibition, at one concentration (the size of the read-out at that concentration, not a potency): 64.9%
Compound 4: the middle estimate sits 37.9 percentage points below what was measured; the measured number lies above the stated range.
By their numbers in this assay, from the lowest: compounds 1 and 3 (each within the scatter of the next); then compounds 2 and 4 (each within the scatter of the next).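

In this assay this position turns out to be sensitive to the group it carries, as shown by a number 39.1 percentage points higher from compound 3 to compound 4 (beyond the scatter) and by a number 40.6 percentage points higher from compound 1 to compound 4 (beyond the scatter); the close match between bromo and nitro therefore does not extend to every small group placed para to a large group on this ring. The six-membered ring on the carbonyl also no longer goes with a low number in every case, since 4-methylphenyl and thiophen-2-yl sit together with a number 4.1 percentage points higher from compound 2 to compound 4 (within the scatter), while compound 1 and compound 3 remain the low examples that carry a six-membered ring there. No measurement at hand addresses what lies behind the gap between methyl and the other two groups.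

Still open, on these data alone, is whether an ethyl group, a methoxy group, chloro or an amine at this same place would read like methyl or like bromo and nitro, which would show how far the effect seen with methyl reaches. As far as these compounds go, these readings also come from one concentration and are not potencies, so how compound 2 and compound 4 would compare as potencies remains unknown.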